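Replacing methylsulfonyl with methoxy on the ketone-bearing heterocycle

The source may report more compounds than this note shows. Statements on the series, on what has been measured and on what is new or still open speak of the compounds shown alone.

Of the compounds shown here, three have been measured in an assay on HEK-293T cells for inhibition of diacylglycerol lipase-alpha (Homo sapiens), read by colorimetric assay; on this read-out lower numbers stand for stronger inhibition and higher numbers for weaker inhibition. Compound 1 `O=C(CCCCCc1ccccc1)c1nc2ccccc2[nH]1` gives 12000 nM, compound 2 `O=C(CCCCCc1ccccc1)c1nc2ncccc2[nH]1` gives 1230 nM, and compound 3 `CS(=O)(=O)c1coc(C(=O)CCCCCCc2ccccc2)n1` gives 389 nM. Compound 3 thus shows the lowest number of the three; its gap to compound 2, the nearest, and its larger gap to compound 1 both lie beyond the scatter. Compound 4 `COc1coc(C(=O)CCCCCCc2ccccc2)n1` has not been measured. It differs from compound 3 in one place: methoxy in place of methylsulfonyl on an aromatic carbon. Among the measured compounds shown here, no pair of measured compounds shows this change, so its size cannot be read from the data. The step expected in this assay is a 3.9-fold higher number from compound 3 to compound 4 (0.59 log units; beyond the scatter), toward a higher number and beyond the scatter. For compound 4 the estimate is 1500 nM, with a range from 400 nM to 6000 nM.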

Compound 4, half-maximal inhibitory concentration: > 10000 nM
Compound 4 was reported as a limit (the forecaster's own chance of this, stated with the estimate: 5%); middle value at least 6.6-fold (0.82 log units) from the limit.
By their numbers in this assay, from the lowest: compound 3; then compound 2; then compound 1.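

Among the compounds shown here, this is the first single change that can be read at this position: on the aromatic carbon next to the ring nitrogen, methoxy in place of methylsulfonyl gives an at least 25-fold higher number from compound 3 to compound 4 (1.41 log units; beyond the scatter) in this assay. With the chain and the rest of the ring unchanged, the inhibition seen for compound 3 depends strongly on the group at this carbon. The value of compound 4 is a limit, so the step has no upper end: the limit of > 10000 nM in this assay, at which 1 of the 4 values shown sits.

The compounds shown leave open how a nitrile, an amide or a carboxylic acid would behave on this carbon. They also leave open whether a plain hydrogen there would match either compound.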